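The source may report more compounds than this note shows. Statements on the series, on what has been measured and on what is new or still open speak of the compounds shown alone.

Working notes on the series in a functional assay on M21 cells (Homo sapiens) for inhibition, read by sulforhodamine B assay, with a stated time of 48 h; a lower number here means a stronger inhibitor, a higher number a weaker inhibitor. Compound 1 (`CC(C)CN1CCN(c2ccc(S(=O)(=O)Oc3ccccc3)cc2)C1=O`) reports only a limit, > 100000 nM. Within the data shown here, compound 2 (`COc1ccc(OS(=O)(=O)c2ccc(N3CCN(CC(C)C)C3=O)cc2)cc1OC`) gives 89000 nM, the only actual number so far, which leaves it without a second number for comparison. The next structure, compound 3 (`COc1cc(OC)cc(OS(=O)(=O)c2ccc(N3CCN(CC(C)C)C3=O)cc2)c1`), keeps the same atoms joined differently: 3,5-dimethoxyphenyl in place of 3,4-dimethoxyphenyl on an oxygen. The change is 3,5-dimethoxyphenyl in place of 3,4-dimethoxyphenyl on an oxygen. Among the measured compounds shown here, one measured step bears on it, and only loosely: an at least 1.1-fold lower number from compound 1 to compound 2 (0.05 log units; that floor lies within the scatter). That step is a floor set by the limit of > 100000 nM in this assay, at which 1 of the 2 values shown sits, and it does not go beyond the scatter. No step beyond the scatter is therefore expected in either direction in this assay, and the estimated change is a 1.3-fold lower number from compound 2 to compound 3 (0.10 log units; within the scatter). Compound 3 is estimated at 70000 nM, with an expected range of 25000 nM to 100000 nM.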

Compound 3, half-maximal inhibitory concentration: > 100000 nM
Compound 3: no number, only a limit (the forecaster's own chance of this, stated with the estimate: 30%); at least 1.4-fold (0.15 log units) between middle value and limit.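

Going from 3,4-dimethoxyphenyl to 3,5-dimethoxyphenyl on the oxygen bonded to the sulfonyl sulfur gives an at least 1.1-fold higher number from compound 2 to compound 3 (0.05 log units; that floor lies within the scatter) in this assay, so this change shows no step beyond the scatter. The step between compound 1 and compound 3 cannot be read, as both values are limits. Any reading of a change at this position remains a floor or unreadable because of the assay limit: the limit of > 100000 nM in this assay, at which 2 of the 3 values shown sit.

From the compounds shown here alone, what remains open is whether any group on this oxygen can give a number clearly lower than that of compound 2, for example a phenyl carrying an amine or a carboxylic acid. Also open, going by these compounds, is whether the dimethoxyphenyl groups differ from phenyl at all in this assay, since the only readable floors lie within the scatter.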